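Working notes: amine alkylation steps in the series

A few compounds are considered here, and "the series" means these few. Any claim that something is new, unique, unknown or untested is made for them only; others in the source may bear on it.

Measured so far in a functional assay for agonist activity at 5-hydroxytryptamine receptor 1B (Homo sapiens); on this read-out lower numbers stand for stronger inhibition and higher numbers for weaker inhibition:
compound 1 `CNCCCOc1ccccc1` gives 3450 nM
compound 2 `CNCCOc1cccc2ccccc12` gives 26 nM
compound 3 `CCNCCOc1cccc2ccccc12` gives 66 nM

Compound 3 holds the second highest of the three numbers in this assay; compound 2 lies below it and compound 1 far above it. Compound 4 `CC(C)NCCOc1cccc2ccccc12` differs from compound 3 by methyl in place of hydrogen on a saturated chain carbon bound to an amine nitrogen and a saturated chain carbon. Among the measured compounds shown here, the one measured step that bears on this change is a 2.5-fold higher number from compound 2 to compound 3 (0.40 log units; beyond the scatter), the same kind of alkylation at the amine. A further step of similar size and in the same direction is therefore expected in this assay, though a single precedent leaves the size uncertain. The step expected from compound 3 to compound 4 is a 2.3-fold higher number from compound 3 to compound 4 (0.36 log units; beyond the scatter). Compound 4 is estimated at 150 nM, with a range from 60 nM to 400 nM.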

Compound 4, inhibition constant: 120 nM
Compound 4: the middle estimate sits 1.3-fold (0.10 log units) above what was measured, within the range that was stated.
By their numbers in this assay, from the lowest: compound 2; then compounds 3 and 4 (each within the scatter of the next); then compound 1.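

In this assay, ethyl to isopropyl on the amine nitrogen gives a 1.8-fold higher number from compound 3 to compound 4 (0.26 log units; within the scatter), so this branching step alone cannot be told apart from repeat scatter. Across the whole series of amine substituents, the change shows only as isopropyl in place of methyl, a 4.6-fold higher number from compound 2 to compound 4 (0.66 log units; beyond the scatter). Compound 4 thus adds a branched substituent at this position, and the difference from methyl remains readable there.

As far as these compounds go, whether a tert-butyl or cyclopropyl group on the amine nitrogen, or the unsubstituted primary amine, would fit these steps stays open. Nothing on hand accounts for the size of these steps.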